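A few compounds are considered here, and "the series" means these few. Any claim that something is new, unique, unknown or untested is made for them only; others in the source may bear on it.

Measured so far:
Compound 1 `COc1nc(-c2ccsc2)ccc1[C@@H](c1ccccc1)[C@@](O)(CCN(C)C)c1cccc2ccccc12` gives 24.4 ug/mL in a toxicity assay on Vero cells (Chlorocebus sabaeus) for cytotoxicity; on this read-out higher numbers stand for lower toxicity in this test and lower numbers for higher toxicity in this test.
Compound 2 `COc1ncc(-c2ccccc2)cc1[C@@H](c1ccccc1)[C@@](O)(CCN(C)C)c1cc(F)cc(F)c1` gives > 50 ug/mL in this assay.

The value for compound 2 is a limit of the assay rather than a number. Compound 1 therefore carries the only number shown, and the one other result, the limit (the limit of > 50 ug/mL in this assay, at which 1 of the 2 values shown sits), offers no measured step against which a change could be judged. Compound 3 `COc1nc(-c2ccccc2Cl)ccc1[C@@H](c1ccccc1)[C@@](O)(CCN(C)C)c1cccc2ccccc12` has not yet been tested in this assay. It differs from compound 1 in a single place: 2-chlorophenyl in place of thiophen-3-yl on an aromatic carbon. Going by the values given here, with no measured pair showing the effect of such a swap on this read-out, the expectation rests on compound 1 alone. A small step is expected, a 1.2-fold lower number from compound 1 to compound 3 (0.09 log units; within the scatter), roughly the size of the usual scatter, with a slight lean toward more toxicity. Compound 3 is estimated to give 20 ug/mL in this assay, within a likely range from 10 ug/mL to 45 ug/mL.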

Compound 3, half-maximal cytotoxic concentration: > 50 ug/mL
Compound 3: only a limit was reported; the forecaster's own chance of this, stated with the estimate: 15%; middle value at least 2.5-fold (0.39 log units) from the limit.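

In this assay, swapping the group on this aromatic carbon, next to the ring nitrogen, can now be read as a single change: 2-chlorophenyl in place of thiophen-3-yl gives an at least 2.0-fold higher number from compound 1 to compound 3 (0.31 log units; beyond the scatter). The result for compound 3, > 50 ug/mL, is a limit of the assay and not a number. This position is therefore not neutral in this test, since changing this one group on the core of compound 1 moves the read-out toward lower toxicity, by an amount known only as a minimum.

Whether the chlorine or the larger carbon-only ring accounts for the step stays open, and a plain phenyl or a carboxylic acid at this position would help separate the two. How far any further change can be followed is also unclear, as results are gathering at the top of the scale: the limit of > 50 ug/mL in this assay, at which 2 of the 3 values shown sit.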